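This account rests on a few compounds, and the source may have more. Where it says the series, first, only, none or still open, it means among the compounds named here.

In a functional assay on B16-F10 cells (Mus musculus) for inhibition, with a stated time of 4 days (a higher number here means a weaker inhibitor, a lower number a stronger inhibitor), compound 1 (`CCc1ccccc1/C=C/C(=O)c1c(O)cc(OC)cc1OC`) gives 2500 nM, compound 2 (`COc1cc(O)c(C(=O)/C=C/c2ccccc2C)c(OC)c1`) gives 3000 nM and compound 3 (`COc1cc(O)c(C(=O)/C=C/c2ccccc2OC)c(OC)c1`) gives 3800 nM. Compound 3 thus stands within the scatter of both others. Compound 4 (`COc1cc(O)c(C(=O)/C=C/c2ccccc2C(C)C)c(OC)c1`) has isopropyl in place of methoxy on an aromatic carbon. The nearest evidence is the exchange of alkyl groups and methoxy at this place, with a 1.5-fold higher number from compound 1 to compound 3 (0.18 log units; within the scatter) and a 1.3-fold higher number from compound 2 to compound 3 (0.10 log units; within the scatter). Among the alkyl groups, the series shows a 1.2-fold higher number from compound 1 to compound 2 (0.08 log units; within the scatter). All three steps lie within the scatter, so no step beyond the scatter is expected in this assay, only a slight drift towards the alkyl compounds. The expected step is a 1.4-fold lower number from compound 3 to compound 4 (0.15 log units; within the scatter). For compound 4 the estimated value is 2700 nM, with an expected range of 1300 nM to 5500 nM.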

Compound 4, half-maximal inhibitory concentration: 2700 nM
Estimate against measurement, compound 4: no gap at the digits printed; the range from low to high includes it.
By their numbers in this assay, from the lowest: compounds 1, 4, 2 and 3 (each within the scatter of the next).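

In this assay, isopropyl on this aromatic carbon gives a 1.4-fold lower number from compound 3 to compound 4 (0.15 log units; within the scatter), a 1.1-fold lower number from compound 2 to compound 4 (0.05 log units; within the scatter) and a 1.1-fold higher number from compound 1 to compound 4 (0.03 log units; within the scatter). The branched group with three heavy atoms therefore extends the earlier picture: ethyl, methyl, methoxy and isopropyl at this position all lie within the scatter of one another. No measurement at hand accounts for this flat result. From the compounds shown here alone, what an amine, a carboxylic acid or a longer chain such as hexyl would give at this position remains open, as does whether any group here can move the number beyond the scatter.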